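Bromo for Ethynyl on a Two-Ring Core

The source may report more compounds than this note shows. Statements on the series, on what has been measured and on what is new or still open speak of the compounds shown alone.

Compound 1, `C#Cc1nc2ccccc2n1C`: 8140 nM
Compound 2, `Ic1nc2ccccc2o1`: 11700 nM
Compound 3, `Ic1nc2ccccc2s1`: > 40000 nM

Of the compounds shown here, three have been measured in a functional assay on NCI-H522 cells (Homo sapiens) for cytotoxicity, with a stated time of 3 days; a lower number here means a stronger inhibitor, a higher number a weaker inhibitor. Compound 1 gives 8140 nM, the lowest of the two numbers, and its nearest neighbour is compound 2 at 11700 nM, a gap that lies within the scatter, so the two cannot be ordered. Compound 3 returns only a limit of the assay, > 40000 nM, as noted in the limit of > 40000 nM in this assay, at which 1 of the 3 values shown sits.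

Compound 4, `Cn1c(Br)nc2ccccc21`, has not yet been measured. It differs from compound 1 by a single change: bromo in place of ethynyl on an aromatic carbon. Among the measured compounds shown here, no two measured compounds differ in one place, so no measured step can guide this one. With the change confined to one small group on the shared core, and with compound 1 itself at 8140 nM, the account expects no step beyond the scatter, perhaps a slight weakening. Compound 4 is therefore estimated at 12000 nM, in a range from 4000 nM to 35000 nM, which corresponds to an expected step of a 1.5-fold higher number from compound 1 to compound 4 (0.17 log units; within the scatter).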

Compound 4, half-maximal inhibitory concentration: > 40000 nM
Compound 4 ended at the assay's limit; the forecaster's own chance of this, stated with the estimate: 15%; middle value at least 3.3-fold (0.52 log units) from the limit.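

In this assay, among the compounds shown here, bromo in place of ethynyl on an aromatic carbon gives an at least 4.9-fold higher number from compound 1 to compound 4 (0.69 log units; beyond the scatter), the first single-place change in this set and one that lies beyond the scatter. The group on this carbon, between the two ring nitrogen atoms, therefore matters for the read-out, since the shared core with a methyl group alone does not keep the number of compound 1. Compound 4 gives a limit and not a number, so only a minimum size of the step can be read: the limit of > 40000 nM in this assay, at which 2 of the 4 values shown sit.

A single step cannot separate the triple bond of ethynyl from its two carbons as what counts here. From the compounds shown here alone, whether a nitrile, an amine or a longer chain on this carbon would stay near compound 1 or reach the limit remains open.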